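Extending the ether substituent of compound 3

A few compounds are considered here, and "the series" means these few. Any claim that something is new, unique, unknown or untested is made for them only; others in the source may bear on it.

Compound 1 `O=C(/C=C/c1ccc(O)cc1)c1c(O)cccc1OCC1CCCCC1`: in a functional assay on PC-3 cells (Homo sapiens) for antiproliferative activity, read by sulforhodamine B assay (on this read-out lower numbers stand for stronger inhibition of growth and higher numbers for weaker inhibition of growth), compound 1 gives > 30000 nM, a limit of the assay.
Compound 2 `O=C(/C=C/c1ccc(O)cc1)c1c(O)cccc1OCc1ccccc1`: in this assay compound 2 gives > 30000 nM, likewise a limit.
Compound 3 `O=C(/C=C/c1ccc(O)cc1)c1c(O)cccc1OCC1CCCC1`: in this assay compound 3 gives 3040 nM.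

Going by the values given here, compound 3 thus holds the only real number in this assay; the two other values are the limit of > 30000 nM in this assay, at which 2 of the 3 values shown sit. Compound 4 `O=C(/C=C/c1ccc(O)cc1)c1c(O)cccc1OCCC1CCCCC1` differs from compound 3 by cyclohexylmethyl in place of cyclopentyl on a saturated chain carbon bound to an oxygen on an aromatic ring. Among the compounds with values here, two measured steps bear on this: an at least 9.8-fold lower number from compound 1 to compound 3 (0.99 log units; beyond the scatter) and an at least 9.8-fold lower number from compound 2 to compound 3 (0.99 log units; beyond the scatter), both reached by arriving at cyclopentyl from a larger group. Compound 4 moves the other way, into a still larger cyclohexylmethyl, so the step is expected to be a 9.9-fold higher number from compound 3 to compound 4 (0.99 log units; beyond the scatter), beyond the scatter and upward. Compound 4 is therefore estimated at 30000 nM in this assay, with a range from 8000 nM to 100000 nM, and a limit is quite likely.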

Compound 4, concentration for 50% growth inhibition: > 30000 nM
Compound 4 was reported as a limit (the forecaster's own chance of this, stated with the estimate: 60%); the middle value lies on the limit itself.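

Replacing cyclopentyl with cyclohexylmethyl on the saturated chain carbon bound to an oxygen on an aromatic ring gives an at least 9.8-fold higher number from compound 3 to compound 4 (0.99 log units; beyond the scatter), so the cyclopentylmethyl ether keeps its edge over a longer 2-cyclohexylethyl ether as well. The steps from compound 1 and from compound 2 to compound 4 cannot be read, as both ends are limits. Compound 3 remains the only compound with a real number: the limit of > 30000 nM in this assay, at which 3 of the 4 values shown sit.

Going by these compounds, whether a smaller cyclobutyl or cyclopropyl group would keep or improve on compound 3 stays open. So does the effect of an open isobutyl chain or a terminal amine at this place.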